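From Bromo to Propyl at the Assay Limit

A few compounds are considered here, and "the series" means these few. Any claim that something is new, unique, unknown or untested is made for them only; others in the source may bear on it.

In a functional assay on MGC-803 cells (Homo sapiens) for antiproliferative activity, read by CCK-8 assay, with a stated time of 72 h (a lower number here means a stronger inhibitor, a higher number a weaker inhibitor), compound 1 `Nc1ccccc1NC(=O)c1ccc(COc2ccc(Br)cc2)cc1` gives > 32000 nM as its reading, which is a limit and not a number. Compound 2 `Nc1cnccc1NC(=O)/C=C/c1ccc(COc2ccccc2)cc1` gives > 32000 nM as its reading, again a limit. That leaves the limit of > 32000 nM in this assay, at which 2 of the 2 values shown sit, as the whole record so far. Compound 3 `CCCc1ccc(OCc2ccc(C(=O)Nc3ccccc3N)cc2)cc1` has propyl in place of bromo on an aromatic carbon, para to a large group (propyl in place of bromo on an aromatic carbon). Going by the values given here, with no measured step to lean on, only a modest gain toward stronger inhibition is expected, and an at least 1.4-fold lower number from compound 1 to compound 3 (0.16 log units; that floor lies within the scatter) is the estimated step in this assay here. Compound 3 is expected at 22000 nM with an estimated range from 8000 nM to 32000 nM in this measurement.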

Compound 3, half-maximal inhibitory concentration: 4420 nM
Estimate against measurement, compound 3: 5.0-fold (0.70 log units) above; measured number below the stated range.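

In this assay, propyl in place of bromo on an aromatic carbon, para to a large group, gives an at least 7.2-fold lower number from compound 1 to compound 3 (0.85 log units; beyond the scatter), the first sign that this position can change the reading. The reading of compound 1 is a limit, so this step states only a minimum size. Compound 3 is the only compound shown with a number rather than a limit: the limit of > 32000 nM in this assay, at which 2 of the 3 values shown sit.

The compounds shown leave open whether a longer chain, such as butyl, would lower the number further. They also leave open how an amine or a carboxylic acid at this position would read.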